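The compounds below may be only part of what the source reports. "The series", "measured", "known", "first", "only" and "open" are said of these compounds alone.

In a functional assay on MCF7 cells (Homo sapiens) for antiproliferative activity (on this read-out lower numbers stand for stronger inhibition and higher numbers for weaker inhibition), compound 1 (`COc1ccc(C(=O)Nc2cc3ccc(OC4CCN(C)CC4)c(C)c3oc2=O)cc1CC=C(C)C`) gives 1580 nM while compound 2 (`C#CCOc1ccc(C(=O)Nc2cc3ccc(OC4CCN(C)CC4)c(C)c3oc2=O)cc1CC=C(C)C`) gives 1120 nM and compound 3 (`CC(C)=CCc1cccc(C(=O)Nc2cc3ccc(OC4CCN(C)CC4)c(C)c3oc2=O)c1`) gives 2100 nM on the same read-out. Compound 1 thus stands level with both relatives, since no gap among the three exceeds the scatter. Compound 4 (`COc1ccc(C(=O)Nc2cc3ccc(OC4CCN(C)CC4)c(C)c3oc2=O)cc1-c1cccc(OC(C)=O)c1`) carries 3-acetoxyphenyl in place of 3-methylbut-2-en-1-yl on an aromatic carbon ortho to a methoxy group. Among the measured compounds shown here, no measured step touches this place. All three alter or remove the methoxy group and leave 3-methylbut-2-en-1-yl untouched, so they bear on the change only indirectly. They show a 1.4-fold lower number from compound 1 to compound 2 (0.15 log units; within the scatter) and a 1.3-fold higher number from compound 1 to compound 3 (0.12 log units; within the scatter) and a 1.9-fold higher number from compound 2 to compound 3 (0.27 log units; within the scatter) in turn. The data therefore give no direction for this replacement, and no step beyond the scatter is expected in this assay although the uncertainty is wide. The expected step is a small one (a 1.4-fold lower number from compound 1 to compound 4 (0.16 log units; within the scatter)) as estimated here. For compound 4 the expected value is 1100 nM within an estimated range of 300 nM to 3500 nM overall.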

Compound 4, half-maximal inhibitory concentration: 360 nM
Compound 4: the middle estimate sits 3.1-fold (0.49 log units) above what was measured; measured number inside the range.
By their numbers in this assay, from the lowest: compound 4; then compounds 2, 1 and 3 (each within the scatter of the next).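

In this assay, among the compounds shown here, the aromatic carbon ortho to a methoxy group proves responsive to replacement: a 4.4-fold lower number from compound 1 to compound 4 (0.64 log units; beyond the scatter) is a step beyond the scatter, whereas the earlier compounds, which all keep 3-methylbut-2-en-1-yl there, stay within the scatter of one another. The change replaces a ring-free group of 5 heavy atoms with 3-acetoxyphenyl, which has 10 heavy atoms, one six-membered aromatic ring and 2 hydrogen-bond acceptors, and the lower number shows that this larger group is accepted at this position on this read-out. Nothing available explains why the number falls.

The compounds shown do not separate the contribution of the phenyl ring from that of the acetoxy group, so it remains open how plain phenyl, or phenyl carrying a hydroxyl or an amine in place of acetoxy, would compare. From the compounds shown here alone, it also remains open whether the replacement would give a similar step with propargyloxy in place of the methoxy group.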